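The source may report more compounds than this note shows. Statements on the series, on what has been measured and on what is new or still open speak of the compounds shown alone.

Measured in an ADME assay on A549 cells (Homo sapiens) for cytotoxicity, read by MTT assay, with a stated time of 4 days; a higher number here means a weaker inhibitor, a lower number a stronger inhibitor:
compound 1, `COc1cc(C[C@H]2C(=O)OC[C@@H]2Cc2ccc(OC)c(OC)c2)ccc1N`, gives > 50000 nM, a limit of the assay.
compound 2, `COc1cc(C[C@H]2C(=O)OC[C@@H]2Cc2ccc(OC)c(OC)c2)ccc1Nc1ccccc1`, gives > 50000 nM, a limit of the assay.
compound 3, `COc1ccc(Nc2ccc(C[C@H]3C(=O)OC[C@@H]3Cc3ccc(OC)c(OC)c3)cc2OC)cc1`, gives > 50000 nM, a limit of the assay.

Among the measured compounds shown here, compound 2 therefore stands at the limit, and so do the other two; no compound of the three gives a number (the limit of > 50000 nM in this assay, at which 3 of the 3 values shown sit). The step from compound 2 to compound 4, `COc1cccc(C[C@H]2C(=O)OC[C@@H]2Cc2ccc(OC)c(OC)c2)c1`, is hydrogen in place of anilino on an aromatic carbon: the whole anilino group is taken off and the aromatic carbon carries only hydrogen.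

For the measured compounds named here, three measured steps touch the same part of the molecule: a step that the two limits leave unreadable from compound 1 to compound 2, a step that the two limits leave unreadable from compound 1 to compound 3 and a step that the two limits leave unreadable from compound 2 to compound 3. None of them has a readable size, so nothing shows how far any change at this position moves the read-out; the series as measured is flat at the limit. The change toward compound 4 is of the same kind, a change on this aromatic carbon, so no step beyond the scatter is expected in this assay, in either direction, and the result is most likely again a limit.

Compound 4 is therefore expected at 50000 nM, with a range of 20000 nM to 120000 nM. That estimate means a number no higher from compound 2 to compound 4 (the limit leaves the size open).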

Compound 4, half-maximal inhibitory concentration: > 50000 nM
Compound 4: only a limit was reported; the forecaster's own chance of this, stated with the estimate: 85%; the middle value sits exactly at the limit.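

Compound 4 joins compounds 1, 2 and 3, so no step among these four compounds can be read in this assay, neither for removing the anilino group nor for any other change at this aromatic carbon: the limit of > 50000 nM in this assay, at which 4 of the 4 values shown sit.

The compounds shown leave open whether any change at this position moves the half-maximal inhibitory concentration at all; none of them gives a number.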